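From chloro to methoxy at a cytotoxicity limit

The source may report more compounds than this note shows. Statements on the series, on what has been measured and on what is new or still open speak of the compounds shown alone.

Compound 1 `N#C/C(=C\c1cn(Cc2ccc(Cl)cc2)c2ccc(Br)cc12)C(=O)c1c[nH]c2ccccc12`: 14000 nM (a number)
Compound 2 `N#C/C(=C\c1cn(Cc2ccc(Cl)cc2)c2ccccc12)C(=O)c1c[nH]c2cc(F)ccc12`: > 50000 nM (a limit)
Compound 3 `N#C/C(=C\c1cn(Cc2ccc(Cl)cc2)c2ccccc12)C(=O)c1c[nH]c2ccccc12`: > 50000 nM (a limit)

In a functional assay on A549 cells (Homo sapiens) for cytotoxicity, read by WST assay, with a stated time of 24 h (a higher number here means a weaker inhibitor, a lower number a stronger inhibitor), compound 3 gives > 50000 nM as a limit of the assay and not as a number. Only compound 1 gives a true number, with 14000 nM as its reading.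

Compound 4 `COc1ccc(Cn2cc(/C=C(\C#N)C(=O)c3c[nH]c4ccccc34)c3ccccc32)cc1` differs from compound 3 in one place methoxy in place of chloro on an aromatic carbon and carries methoxy in place of chloro on an aromatic carbon, so 4-chlorobenzyl becomes 4-methoxybenzyl.

Two measured steps lie elsewhere on the molecule. Removing bromo gives an at least 3.5-fold higher number from compound 1 to compound 3 (0.55 log units; beyond the scatter) as its step, while removing fluoro gives a step that the two limits leave unreadable from compound 2 to compound 3 as its step. Neither touches the 4-chlorobenzyl group, so neither sets a size for this change. Compounds 2 and 3 both lack bromo and sit at the limit of > 50000 nM in this assay, at which 2 of the 3 values shown sit, in the data so far. Compound 4 lacks bromo as well, so no step beyond the scatter is expected in either direction. The expected step is a number no higher from compound 3 to compound 4 (the limit leaves the size open) on this estimate. For compound 4 the estimated value is 50000 nM with an expected range from 20000 nM to 100000 nM as the likely span.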

Compound 4, half-maximal inhibitory concentration: > 50000 nM
Compound 4 was reported as a limit (the forecaster's own chance of this, stated with the estimate: 70%); the middle value sits exactly at the limit.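

In this assay compound 4 gives > 50000 nM, a limit of the assay and not a number. Compound 3 also reads as a limit, so no step can be read between compound 3 and compound 4: the limit of > 50000 nM in this assay, at which 3 of the 4 values shown sit.

The compounds shown leave open how 4-chlorobenzyl and 4-methoxybenzyl compare on a core that gives a true number, such as that of compound 1.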